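Replacing a halogenated ring with a dihydroxylated ring

The compounds below may be only part of what the source reports. "The series", "measured", "known", "first", "only" and "open" are said of these compounds alone.

Compound 1 `COc1cccc(CNc2ncnc3c2ncn3[C@@H]2O[C@H](CO)[C@@H](O)[C@H]2O)c1`: "not determined" (no result reported)
Compound 2 `OC[C@H]1O[C@@H](n2cnc3c(NCc4ccc(F)c(Cl)c4)ncnc32)[C@H](O)[C@@H]1O`: > 166000 nM

Both entries come from a functional assay on G-361 cells (Homo sapiens) for antiproliferative activity, with a stated time of 72 h; on this read-out higher numbers stand for weaker inhibition and lower numbers for stronger inhibition. Compound 1 gives no result to compare with, so the story rests on compound 2 alone. In this test, compound 2 stands at > 166000 nM. That value is a limit of the assay, not a number.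

Compound 3 `OC[C@H]1O[C@@H](n2cnc3c(NCc4cc(O)cc(O)c4)ncnc32)[C@H](O)[C@@H]1O` keeps the core of compound 2 and differs in one place: 3,5-dihydroxyphenyl in place of 3-chloro-4-fluorophenyl on a saturated chain carbon bound to a nitrogen on an aromatic ring. The swap puts 3,5-dihydroxyphenyl in place of 3-chloro-4-fluorophenyl on a saturated chain carbon bound to a nitrogen on an aromatic ring.

For the measured compounds named here, no measured step guides the forecast, so it is a cautious one, and a second limit is quite possible. The expected change is modest, towards stronger inhibition: an at least 2.3-fold lower number from compound 2 to compound 3 (0.37 log units; beyond the scatter). For compound 3 the estimated value is 70000 nM, with an expected range of 12000 nM to 166000 nM.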

Compound 3, half-maximal inhibitory concentration: > 166000 nM
Compound 3 gave a limit, no number; the forecaster's own chance of this, stated with the estimate: 55%; middle value at least 2.3-fold (0.37 log units) away from the limit.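

Compound 3 gives > 166000 nM in this assay, again a limit and not a number. Compound 2 also sits at a limit, so no step can be read from compound 2 to compound 3: the limit of > 166000 nM in this assay, at which 2 of the 3 values shown sit.

From the compounds shown here alone, what stays open is how strongly either compound inhibits, and whether swapping 3-chloro-4-fluorophenyl for 3,5-dihydroxyphenyl changes that at all.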